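Shortening the side chain of compound 2 by one carbon

This account rests on a few compounds, and the source may have more. Where it says the series, first, only, none or still open, it means among the compounds named here.

Of the compounds shown here, three have been measured so far in a functional assay on the whole organism (Tail, strain ICR) with Mus musculus as the target, in the tail flick test, with a stated time of 120 min, at a dose of 25 umol/kg by the oral route; on this read-out lower numbers stand for a weaker effect and higher numbers for a stronger effect at the one dose given. Compound 1, `C[C@H](NC(=O)CN(c1ncnc2c1ncn2C1CCCCO1)C1CC1)C(=O)OCc1ccccc1`, gives 25.3%. Compound 2, `NC(=O)CC[C@H](NC(=O)CN(c1nc(Cl)nc2[nH]cnc12)C1CC1)C(=O)O`, gives 17.8%. Compound 3, `NC(=O)CC[C@H](NC(=O)CN(c1nc(Cl)nc2[nH]cnc12)C1CC1)C(=O)OCc1ccccc1`, gives 36%. Compound 2 thus stands lowest of the three numbers; compound 1 lies nearest to it, within the scatter, and compound 3 lies furthest, beyond the scatter. Among the measured compounds shown here, the one step described among measured pairs is a number 18.2 percentage points higher from compound 2 to compound 3 (beyond the scatter), brought about by benzyl in place of hydrogen on an oxygen next to a carbonyl group.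

The next compound, compound 4, is `NC(=O)C[C@H](NC(=O)CN(c1nc(Cl)nc2[nH]cnc12)C1CC1)C(=O)O`. It differs from compound 2 by carbamoyl in place of carbamoylmethyl on a saturated chain carbon, two bonds along the chain from an amide-type nitrogen and a carbonyl carbon. This change sits on the side chain and leaves the acid and the rest of compound 2 untouched. For the measured compounds named here, no measured step in this assay concerns the side chain: the only step known, from compound 2 to compound 3, changes the ester end and gives no hint about the chain length. With nothing to go on but the value of compound 2, no step beyond the scatter is expected in this assay, and the estimated step of a number 1.2 percentage points higher from compound 2 to compound 4 (within the scatter) is small. Compound 4 is therefore expected to give about 19%, with a range from 8% to 31%.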

Compound 4, a percentage reported as activity, at one dose (the size of the read-out at that dose, not a potency): 17%
Compound 4: the middle estimate sits 2 percentage points above what was measured, and the stated range covers the measured number.
By their numbers in this assay, from the lowest: compounds 4, 2 and 1 (each within the scatter of the next); then compound 3.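

In this assay, among the compounds shown here, carbamoyl in place of carbamoylmethyl on a saturated chain carbon, two bonds along the chain from an amide-type nitrogen and a carbonyl carbon, gives a number 0.8 percentage points lower from compound 2 to compound 4 (within the scatter) and is the first reading at this position, so on the free acid the two chain lengths cannot be told apart. Among the compounds that differ in one place, the step at the ester end, a number 18.2 percentage points higher from compound 2 to compound 3 (beyond the scatter), remains the only one beyond the scatter, while this side chain change stays inside it. Nothing measured on these compounds bears on this result.

From the compounds shown here alone, the side chain has been read only on the free acid, so it stays open whether carbamoylmethyl and carbamoyl would also read alike on the benzyl ester of compound 3. Also open, going by these compounds, is what a longer chain, or an amine or a carboxylic acid at the end of the side chain in place of the carbamoyl group, would give, and whether any of these would take the number beyond the scatter.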